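Imidazolyl replacing methylsulfanyl: expected solubility of compound 4

This account rests on a few compounds, and the source may have more. Where it says the series, first, only, none or still open, it means among the compounds named here.

Measured compounds:
- compound 1 `CSc1nc(C(C)(C)C)nc2nc(N)c(C#N)c(N)c12`: 14000 nM
- compound 2 `CCCCc1nc(C(C)(C)C)nc2nc(N)c(C#N)c(N)c12`: 6000 nM
- compound 3 `CC(C)(C)c1nc(-c2cnccn2)c2c(N)c(C#N)c(N)nc2n1`: 86000 nM

The read-out here is a physicochemical assay for solubility, in phosphate buffer, with a stated time of 18 h; on this read-out higher numbers stand for higher solubility and lower numbers for lower solubility. Among the three measured compounds, compound 1 stands second highest: its nearest neighbour is compound 2, a step of a 2.3-fold lower number from compound 1 to compound 2 (0.37 log units; beyond the scatter), and the furthest is compound 3, a step of a 6.1-fold higher number from compound 1 to compound 3 (0.79 log units; beyond the scatter). Compound 2 and compound 3 differ by a 14-fold higher number from compound 2 to compound 3 (1.16 log units; beyond the scatter).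

Compound 4 `Cc1c[nH]c(-c2nc(C(C)(C)C)nc3nc(N)c(C#N)c(N)c23)n1` arises from compound 1 through the change (4-methyl-1H-imidazol-2-yl in place of methylsulfanyl on an aromatic carbon).

The step that bears most directly on this change is the one in which another aromatic ring replaced the same methylsulfanyl group, from compound 1 to compound 3, which was a 6.1-fold higher number from compound 1 to compound 3 (0.79 log units; beyond the scatter); the step from compound 2 to compound 3, a 14-fold higher number from compound 2 to compound 3 (1.16 log units; beyond the scatter), points the same way. An upward step in this assay is therefore expected for compound 4, of roughly the size seen there, estimated as a 4.3-fold higher number from compound 1 to compound 4 (0.63 log units; beyond the scatter). Compound 4 is expected to give about 60000 nM, with a likely range from 15000 nM to 200000 nM.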

Compound 4, solubility: 5000 nM
Estimate against measurement, compound 4: 12-fold (1.08 log units) above, and the stated range ends above it.
By their numbers in this assay, from the lowest: compounds 4 and 2 (each within the scatter of the next); then compound 1; then compound 3.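

In this assay, putting an aromatic ring at this position does not by itself raise the number: the 4-methyl-1H-imidazol-2-yl group gives a 2.8-fold lower number from compound 1 to compound 4 (0.45 log units; beyond the scatter) and so moves the opposite way from pyrazin-2-yl. Which ring is present clearly matters, since exchanging one ring for the other gives a 17-fold lower number from compound 3 to compound 4 (1.24 log units; beyond the scatter) on the same core. The ring also need not differ from a simple chain, as replacing butyl gives only a 1.2-fold lower number from compound 2 to compound 4 (0.08 log units; within the scatter) in this series. No measurement shown explains why the two rings part so widely. Still open, on these data alone, is whether the methyl group on the imidazole ring contributes, and where an unsubstituted imidazol-2-yl, a pyridin-2-yl ring, an amine or a carboxylic acid would fall at this position.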